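Working notes on compounds 1 to 4

A few compounds are considered here, and "the series" means these few. Any claim that something is new, unique, unknown or untested is made for them only; others in the source may bear on it.

All values are from a functional assay on SK-MEL-2 cells (Homo sapiens) for cytotoxicity; on this read-out higher numbers stand for an effect only at larger amounts of compound and lower numbers for an effect already at smaller amounts.
- compound 1, `C=CCCCCCCCC#CC#CCOCC(=O)O`: 4.68 ug/mL
- compound 2, `CCCCCCCC#CC#CCOCC(=O)O`: 7.97 ug/mL
- compound 3, `C=CCCCCCCCC#CC#CCOCC(=O)OC`: > 30 ug/mL, which is a limit of the assay and not a number

Compound 1 and compound 2 differ by hydrogen in place of vinyl on a saturated chain carbon, seven bonds along the chain from a triple-bonded carbon. This step is a 1.7-fold higher number from compound 1 to compound 2 (0.23 log units; within the scatter). Compound 3 carries the core change methyl in place of hydrogen on an oxygen next to a carbonyl group relative to compound 1, and the step is an at least 6.4-fold higher number from compound 1 to compound 3 (0.80 log units; beyond the scatter). For compound 3 only a limit is known, the one at the limit of > 30 ug/mL in this assay, at which 1 of the 3 values shown sits.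

Compound 4, `CCCCCCCC#CC#CCOCC(=O)OC`, is not yet measured in this assay. It differs from compound 3 by hydrogen in place of vinyl on a saturated chain carbon, seven bonds along the chain from a triple-bonded carbon, the same change as from compound 1 to compound 2, made here on the core of compound 3.

In this assay the step from compound 3 to compound 4 is expected to be a step that the limit leaves unreadable from compound 3 to compound 4, because the earlier step of a 1.7-fold higher number from compound 1 to compound 2 (0.23 log units; within the scatter) lay within the scatter. Compound 4 is therefore estimated at 45 ug/mL, between 20 ug/mL and 120 ug/mL, most likely again reported only as a limit.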

Compound 4, concentration for half-maximal effect: > 30 ug/mL
Compound 4 gave a limit, no number (the forecaster's own chance of this, stated with the estimate: 80%); the middle value does not contradict the limit.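

In this assay methyl in place of hydrogen on an oxygen next to a carbonyl group gives an at least 3.7-fold higher number from compound 2 to compound 4 (0.57 log units; beyond the scatter) on the core of compound 2, so the change is also beyond the scatter on this second core. It therefore carries over in direction between the two cores, though no difference in its size can be claimed: the same change on two cores in this assay, an at least 6.4-fold higher number (0.80 log units; beyond the scatter) from compound 1 to compound 3 and an at least 3.7-fold higher number (0.57 log units; beyond the scatter) from compound 2 to compound 4; the limit leaves it open whether they differ. Compound 3 and compound 4 both stand at a limit, the step between them cannot be read, and the size of the change on either core remains only a minimum: the limit of > 30 ug/mL in this assay, at which 2 of the 4 values shown sit.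

Whether vinyl and hydrogen differ on the core of compound 3 stays open, and this end of the chain is shown only as the carboxylic acid and its methyl ester. An amide or an ethyl ester at that end, or a longer chain carrying the same acid, would show whether measurable numbers depend on the free acid or are lost with the methyl ester alone.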